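Formyl in place of hydroxyamino: still at the limit?

The source may hold more compounds than are shown below. What is called first, only, known or untested is meant among the compounds shown, and "the series" means these compounds.

Compound 1 `N#Cc1cc(=O)[nH]c(=O)n1[C@@H]1O[C@H](CO)[C@@H](O)[C@H]1O` and compound 2 `O=c1cc(NO)n([C@@H]2O[C@H](CO)[C@@H](O)[C@H]2O)c(=O)[nH]1` differ in one group on a shared core. In a functional assay on SKW3 cells (Homo sapiens) for antiproliferative activity, read by WST assay, with a stated time of 3 days (a higher number here means a weaker inhibitor, a lower number a stronger inhibitor), compound 1 gives > 50000 nM, which is a limit of the assay. In this assay compound 2 gives > 50000 nM, also a limit, so its place in the series has no number behind it. For the measured compounds named here, the only measured step is a step that the two limits leave unreadable from compound 1 to compound 2, hydroxyamino in place of cyano on an aromatic carbon. The whole record so far is the limit of > 50000 nM in this assay, at which 2 of the 2 values shown sit.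

Compound 3 `O=Cc1cc(=O)[nH]c(=O)n1[C@@H]1O[C@H](CO)[C@@H](O)[C@H]1O` has formyl in place of hydroxyamino on an aromatic carbon. Going by the values given here, no measured step offers a size to carry over, so no clear move in either direction is expected in this assay. The expected change is a number no higher from compound 2 to compound 3 (the limit leaves the size open). For compound 3 the estimate is 50000 nM, with an expected range from 12000 nM to 200000 nM.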

Compound 3, half-maximal inhibitory concentration: > 50000 nM
Compound 3: no number, only a limit; the forecaster's own chance of this, stated with the estimate: 70%; the middle value sits exactly at the limit.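

No step can be read among compound 1, compound 2 and compound 3, as each stands only at a limit in this assay: the limit of > 50000 nM in this assay, at which 3 of the 3 values shown sit.

The compounds shown leave open how cyano, hydroxyamino and formyl rank against one another, and whether any group at this place on the shared core gives a readable value.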